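Isopropyl to dimethylamino: expected step in antiproliferative read-out

The source may report more compounds than this note shows. Statements on the series, on what has been measured and on what is new or still open speak of the compounds shown alone.

In a functional assay on SGC-7901 cells (Homo sapiens) for antiproliferative activity, read by MTT assay, with a stated time of 48 h (on this read-out higher numbers stand for weaker inhibition and lower numbers for stronger inhibition), compound 2 (`CC(C)c1ccc(-c2nnc(SCc3ccc(Cl)nc3)o2)cc1`) gives 4.32 ug/mL. Among the measured compounds shown here, the only other measured member of the series, compound 1 (`Fc1ccc(-c2nnc(SCc3ccc(Cl)nc3)o2)cc1`), gives 3.67 ug/mL. For the measured compounds named here, the single measured step is a 1.2-fold higher number from compound 1 to compound 2 (0.07 log units; within the scatter), with isopropyl in place of fluoro on an aromatic carbon, so the two compounds cannot be separated on these numbers.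

Compound 3 (`CN(C)c1ccc(-c2nnc(SCc3ccc(Cl)nc3)o2)cc1`) carries dimethylamino in place of isopropyl on an aromatic carbon. The change falls on an aromatic carbon of a six-membered aromatic ring of carbon only, para to a large group, the same carbon that changed in the measured step.

Going by the values given here, that step is the only evidence bearing on the new change. Among the compounds with values here, no measured compound has a nitrogen-bearing group at this carbon, so the evidence is thin. Resting on a 1.2-fold higher number from compound 1 to compound 2 (0.07 log units; within the scatter), no step beyond the scatter is expected in this assay. The expected step is a 1.1-fold lower number from compound 2 to compound 3 (0.03 log units; within the scatter). Compound 3 is estimated at 4 ug/mL, with an expected range of 1.8 ug/mL to 9 ug/mL.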

Compound 3, half-maximal inhibitory concentration: 8.9 ug/mL
Beside the measured number, compound 3's estimate is 2.2-fold (0.35 log units) below it; the range from low to high includes it.
By their numbers in this assay, from the lowest: compounds 1 and 2 (each within the scatter of the next); then compound 3.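

In this assay, this aromatic carbon, para to a large group, proves sensitive to the choice of substituent: the step to dimethylamino is a 2.1-fold higher number from compound 2 to compound 3 (0.31 log units; beyond the scatter) when it replaces isopropyl and a 2.4-fold higher number from compound 1 to compound 3 (0.38 log units; beyond the scatter) when it replaces fluoro, so compound 3 is the weakest of the three, by a modest margin, while compound 1 and compound 2 remain inseparable. Among the compounds shown here, the isopropyl to dimethylamino change keeps the heavy-atom count the same and exchanges a carbon for a nitrogen, with a hydrogen-bond acceptor entering, which shows that inhibition can shift at this carbon with no change in that count, whereas fluoro and isopropyl, though they differ in heavy-atom count, gave no separable step. Nothing available here accounts for the loss of inhibition seen with dimethylamino.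

From the compounds shown here alone, whether the weaker inhibition follows from any nitrogen-bearing group at this carbon or is particular to dimethylamino stays open, and a primary amine or a methoxy group at the same carbon would bear on that. The compounds shown also leave open whether any group here can give a clearly lower number than fluoro or isopropyl, such as a nitrile or a carboxylic acid.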